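Working notes: chloro in place of hydrogen on compound 1

The source may hold more compounds than are shown below. What is called first, only, known or untested is meant among the compounds shown, and "the series" means these compounds.

Measured so far in a functional assay on DU-145 cells (Homo sapiens) for cytotoxicity, read by trypan blue exclusion, with a stated time of 96 h; on this read-out higher numbers stand for weaker inhibition and lower numbers for stronger inhibition

- compound 1 `O=S(=O)(/C=C/c1ccccc1)Nc1ccccc1` gives 10000 nM
- compound 2 `COc1ccc(/C=C/S(=O)(=O)Nc2ccc(OC)c(F)c2)cc1` gives 5000 nM
- compound 3 `COc1ccc(/C=C/S(=O)(=O)Nc2c(F)c(F)c(F)c(F)c2F)cc1[N+](=O)[O-]` gives 100000 nM

Compound 1 at 10000 nM cannot be separated from compound 2 at 5000 nM. The gap between these two lies within the scatter. Compound 3 at 100000 nM stands clearly higher than compound 1, beyond the scatter, so compound 1 belongs to the lower part of this small set.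

The next compound is compound 4 `O=S(=O)(/C=C/c1ccccc1)Nc1ccc(Cl)cc1` with chloro in place of hydrogen on an aromatic carbon, para to a large group chloro in place of hydrogen on an aromatic carbon on the core of compound 1. Going by the values given here, no two measured compounds differ in one place only, so the data hold no direct reading of this change. Compounds 2 and 3 differ from compound 1 in several places at once and serve only as loose bounds.

In this assay no step beyond the scatter is expected, with a slight lean towards a lower number. The expected step of a 1.4-fold lower number from compound 1 to compound 4 (0.15 log units; within the scatter) is an estimate and remains tentative. Compound 3 at 100000 nM keeps the upper side of the range wide. For compound 4 the estimated value is 7000 nM with 2500 nM to 20000 nM as the expected range.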

Compound 4, half-maximal inhibitory concentration: 20000 nM
Compound 4: the middle estimate sits 2.9-fold (0.46 log units) below what was measured; the range from low to high includes it.
By their numbers in this assay, from the lowest: compounds 2, 1 and 4 (each within the scatter of the next, the first and the last beyond it); then compound 3.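

Going by these compounds alone, the pair of compound 1 and compound 4 gives the first reading in this assay of a change in one place only, and for chloro in place of hydrogen on an aromatic carbon, para to a large group, that reading is a 2.0-fold higher number from compound 1 to compound 4 (0.30 log units; within the scatter) with all else in the core of compound 1 unchanged. Within the data shown here, at this position, therefore, the single chlorine atom leaves compound 4 inseparable from compound 1 on this read-out, something that compound 2 and compound 3 could not show, as each differs from compound 1 in several places at once. No measurement is at hand that would explain this reading.

On these data alone, whether the same position gives a step beyond the scatter with a different group, such as an amine, a carboxylic acid or a longer chain, remains open. Also open, as far as these compounds go, is whether chloro on another aromatic carbon of the same ring, or on the other aromatic ring of the core of compound 1, would read the same way in this assay as a single change.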